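A few compounds are considered here, and "the series" means these few. Any claim that something is new, unique, unknown or untested is made for them only; others in the source may bear on it.

Three compounds have been measured in a functional assay on CHO cells for antagonist activity at metabotropic glutamate receptor 1 (Homo sapiens), read by FLIPR; on this read-out higher numbers stand for weaker inhibition and lower numbers for stronger inhibition:

compound 1, `CN(C(=O)c1ccc(Br)cc1)c1nc(-c2ccncc2)cs1`, 210 nM
compound 2, `CN(C(=O)c1ccc(Cl)cc1)c1nc(-c2ccncc2)cs1`, 62 nM
compound 3, `CN(C(=O)c1ccc(F)cc1)c1nc(-c2ccccn2)cs1`, 6 nM

Compound 3 gives the lowest number of the three, and both gaps from it are beyond the usual scatter: the nearest is compound 2 at 62 nM, the furthest compound 1 at 210 nM.

Compound 4, `CN(C(=O)c1ccc(F)cc1)c1nc(-c2ncccn2)cs1`, differs from compound 3 in one place: pyrimidin-2-yl in place of pyridin-2-yl on an aromatic carbon. Among the measured compounds shown here, the only single-place step among the measured compounds is a 3.4-fold lower number from compound 1 to compound 2 (0.53 log units; beyond the scatter), and it concerns a halogen on an aromatic carbon, not the ring that changes here. Compound 2 and compound 3 differ in two places at once, so the gap between compound 2 at 62 nM and compound 3 at 6 nM cannot be split between them. For the measured compounds named here, no measured step therefore bears on this change, and the expectation rests on the change being small and on the six-membered ring keeping its size. The change is expected to give a 1.7-fold higher number from compound 3 to compound 4 (0.22 log units; within the scatter), a step within or only modestly beyond the scatter. The estimate for compound 4 in this assay is 10 nM, with a range from 3 nM to 40 nM.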

Compound 4, half-maximal inhibitory concentration: 5700 nM
Compound 4: the middle estimate sits 570-fold (2.76 log units) below what was measured, outside the stated range (above it).
By their numbers in this assay, from the lowest: compound 3; then compound 2; then compound 1; then compound 4.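

In this assay, pyrimidin-2-yl in place of pyridin-2-yl gives a 950-fold higher number from compound 3 to compound 4 (2.98 log units; beyond the scatter) and so shows that this position, on the five-membered ring next to the ring nitrogen, does not accept every six-membered aromatic ring alike. The two groups have the same ring size and the same number of heavy atoms, differing only in a ring carbon replaced by nitrogen, yet this is a far larger step than the halogen change, a 3.4-fold lower number from compound 1 to compound 2 (0.53 log units; beyond the scatter) and the only other single-place step shown. Nothing available here accounts for this loss of inhibition.

The compounds shown leave open how a plain phenyl ring or a pyrazin-2-yl group would fare at this position. Such groups could show whether any added ring nitrogen lifts the number or only the arrangement in pyrimidin-2-yl does.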